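Methyl to chloro on the aryl ring of compound 2

The source may hold more compounds than are shown below. What is called first, only, known or untested is meant among the compounds shown, and "the series" means these compounds.

For the measured compounds named here, compound 2 `Cc1ccc(-c2nc(SCc3cn(CC(=O)NC(=O)Nc4ccccn4)nn3)nc(Nc3ccc(C(C)C)cc3)c2C#N)cc1` gives 7450 nM in a functional assay on ECa-109 cells (Homo sapiens) for inhibition, read by MTT assay, with a stated time of 72 h (a lower number here means a stronger inhibitor, a higher number a weaker inhibitor), the second highest of the three numbers measured so far. Compound 1 `CC(C)c1ccc(Nc2nc(SCc3cn(CC(=O)NC(=O)Nc4ccccn4)nn3)nc(-c3ccc(C(C)C)cc3)c2C#N)cc1` gives 2490 nM in this assay, and compound 3 `COc1ccccc1Nc1nc(SCc2cn(CC(=O)NC(=O)Nc3ccccn3)nn2)nc(-c2ccc(C)cc2)c1C#N` gives 7850 nM. The step of a 3.0-fold higher number from compound 1 to compound 2 (0.48 log units; beyond the scatter) touched the same aromatic carbon that is changed here, whereas the step of a 1.1-fold higher number from compound 2 to compound 3 (0.02 log units; within the scatter) concerned the nitrogen on an aromatic ring and does not bear on this change. Compound 4 `CC(C)c1ccc(Nc2nc(SCc3cn(CC(=O)NC(=O)Nc4ccccn4)nn3)nc(-c3ccc(Cl)cc3)c2C#N)cc1` differs from compound 2 by chloro in place of methyl on an aromatic carbon. Going by the values given here, no measured step exchanges methyl for chloro, and the isopropyl-to-methyl step shows only that this carbon is sensitive. The expected step of a 1.2-fold lower number from compound 2 to compound 4 (0.09 log units; within the scatter) in this assay is therefore small, possibly none beyond the scatter. Compound 4 is estimated at 6000 nM, with a range from 2500 nM to 15000 nM.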

Compound 4, half-maximal inhibitory concentration: > 64000 nM
Compound 4 ended at the assay's limit (the forecaster's own chance of this, stated with the estimate: 5%); middle value at least 10-fold (1.02 log units) from the limit.
By their numbers in this assay, from the lowest: compound 1; then compounds 2 and 3 (each within the scatter of the next). At a limit, above all of these: compound 4.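

In this assay compound 4 gives > 64000 nM, a limit of the assay and not a number. Exchanging one heavy atom on this aromatic carbon gives an at least 8.5-fold higher number from compound 2 to compound 4 (0.93 log units; beyond the scatter), and the exchange of isopropyl for chloro gives an at least 25-fold higher number from compound 1 to compound 4 (1.40 log units; beyond the scatter). Isopropyl and methyl both kept a readable number here, so among compounds 1, 2 and 4 only chloro reaches the limit, which a 3.0-fold higher number from compound 1 to compound 2 (0.48 log units; beyond the scatter) alone did not show.

From the compounds shown here alone, whether the loss is specific to chloro stays open; fluoro, methoxy or an amine on this carbon would test it. Going by these compounds, the full size of both steps also stays unknown.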